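A Smaller Aromatic Ring on a Well-Tolerated Core

The compounds below may be only part of what the source reports. "The series", "measured", "known", "first", "only" and "open" are said of these compounds alone.

Compound 2 `COc1cccc(-c2nc(/C=C/c3cc4ccccc4nc3OC)no2)c1` is the starting point. In an ADME assay on HepG2 cells (Homo sapiens) for cytotoxicity, read by sulforhodamine B assay, with a stated time of 48 h (a lower number here means that less compound is tolerated, a higher number that more compound is tolerated), compound 2 gives > 220000 nM, which is a limit of the assay rather than a number. Compound 1 `COc1nc2ccccc2cc1/C=C/c1noc(-c2ccc(F)cc2)n1` carries 4-fluorophenyl where compound 2 carries 3-methoxyphenyl. In this assay compound 1 likewise gives only a limit, > 230000 nM. The step that the two limits leave unreadable from compound 1 to compound 2 therefore cannot be read, as the limit of > 220000 nM in this assay, at which 1 of the 2 values shown sits, and the limit of > 230000 nM in this assay, at which 1 of the 2 values shown sits, show. Compound 3 `COc1nc2ccccc2cc1/C=C/c1noc(-c2ccco2)n1` carries the change (furan-2-yl in place of 3-methoxyphenyl on an aromatic carbon). With only limits known, no step beyond the scatter is expected. Compound 3 is estimated at 230000 nM, between 100000 nM and 500000 nM, most likely again as a limit. That estimate means an expected step that the limit leaves unreadable from compound 2 to compound 3.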

Compound 3, half-maximal cytotoxic concentration: > 250000 nM
Compound 3 ended at the assay's limit (the forecaster's own chance of this, stated with the estimate: 80%); middle value at least 1.0-fold (0.03 log units) from the limit.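

In this assay, among the compounds shown here, compound 1, compound 2 and compound 3 each give only a limit, and no step among them can be read. The compounds shown leave open whether exchanging these aromatic rings changes how much compound the cells tolerate.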